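Hydroxyalkyl triazole side chains on the amidoxime core

A few compounds are considered here, and "the series" means these few. Any claim that something is new, unique, unknown or untested is made for them only; others in the source may bear on it.

Two members of the series have been run so far in an assay on isolated protein for inhibition of Indoleamine 2,3-dioxygenase 2 (Homo sapiens); on this read-out lower numbers stand for stronger inhibition and higher numbers for weaker inhibition. Compound 1 `OCCCc1cn(CCNc2nonc2/C(=N/O)Nc2ccc(F)c(Br)c2)nn1` carries a 3-hydroxypropyl on the triazole and in this assay gives 958 nM. Compound 2 `OCCCCc1cn(CCNc2nonc2/C(=N/O)Nc2ccc(F)c(Br)c2)nn1` carries 4-hydroxybutyl on the same carbon and in this assay gives 1080 nM. Within the data shown here, the only step measured to date, a 1.1-fold higher number from compound 1 to compound 2 (0.05 log units; within the scatter), shows that adding one chain carbon leaves the number where it was; the two compounds therefore stand side by side, and neither can be set apart from the other.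

Compound 3 `CC(OCCO)c1cn(CCNc2nonc2/C(=N/O)Nc2ccc(F)c(Br)c2)nn1` is not yet measured. It differs from compound 2 by 1-(2-hydroxyethoxy)ethyl in place of 4-hydroxybutyl on an aromatic carbon. Among the measured compounds shown here, the one measured step bears on it only loosely, since it involved chain length alone and was within the scatter; no step has yet moved this assay beyond the scatter. With nothing to point in either direction, the step from compound 2 to compound 3 is expected to be a 1.1-fold higher number from compound 2 to compound 3 (0.05 log units; within the scatter), that is, no change beyond the scatter. Compound 3 is accordingly estimated at 1200 nM, with a range from 500 nM to 3000 nM.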

Compound 3, half-maximal inhibitory concentration: 930 nM
Beside the measured number, compound 3's estimate is 1.3-fold (0.11 log units) above it; the range from low to high includes it.
By their numbers in this assay, from the lowest: compounds 3, 1 and 2 (each within the scatter of the next).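

Working notes on the triazole side chain: in this assay, putting 1-(2-hydroxyethoxy)ethyl on this aromatic carbon of the five-membered ring in place of 4-hydroxybutyl gives a 1.2-fold lower number from compound 2 to compound 3 (0.06 log units; within the scatter), and putting it there in place of 3-hydroxypropyl gives a 1.0-fold lower number from compound 1 to compound 3 (0.01 log units; within the scatter). The earlier pair spoke only to chain length, whereas this change brings in a branched chain with 6 heavy atoms and 2 hydrogen-bond acceptors, against 5 heavy atoms and 1 acceptor for 4-hydroxybutyl, and the number still stays within the scatter of both neighbours, so among these three compounds the position accepts an ether-containing chain as readily as the plain hydroxyalkyl chains. Nothing available explains why the number holds across these chains.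

On these data alone, all three chains end in a hydroxy group, so it remains open whether that hydroxy has any bearing on the number, a question that a chain ending in a methoxy group, a carboxylic acid or an amine would address. Among these compounds, with every step so far inside the scatter, it is also open what kind of group on this carbon, such as a phenyl ring or a much longer chain, would move the number at all.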